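Acetyl for Fluoro on an Aromatic Ring: Cytotoxicity in Insect Cells

A few compounds are considered here, and "the series" means these few. Any claim that something is new, unique, unknown or untested is made for them only; others in the source may bear on it.

Measured so far:
- compound 1, `O=C(/C=C/[C@H]1C[C@@H](O)[C@@H](O)C1)NO`: > 250000 nM
- compound 2, `O=C(/C=C/[C@H]1C[C@@H](O)[C@@H](O)C1)N1CCCCC1`: > 250000 nM
- compound 3, `O=C(/C=C/[C@H]1C[C@@H](O)[C@@H](O)C1)Nc1ccc(F)cc1`: > 180000 nM

All three compounds were tested in an ADME assay on S2 cells (Drosophila melanogaster) for cytotoxicity, read by MTT assay; a higher number here means that more compound is needed for the effect, a lower number that less compound is needed. For compound 1 the result is a limit of the assay, > 250000 nM, not a number. For compound 2 the result is likewise a limit, > 250000 nM. Compound 3 also gives only a limit, > 180000 nM, so its standing among the three is that of one value held at a limit beside two others also held at limits (the limit of > 180000 nM in this assay, at which 1 of the 3 values shown sits; (the limit of > 250000 nM in this assay, at which 2 of the 3 values shown sit)). Within the data shown here, no step between measured compounds can be read from these data.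

The step from compound 3 to compound 4, `CC(=O)c1ccc(NC(=O)/C=C/[C@H]2C[C@@H](O)[C@@H](O)C2)cc1`, is the change (acetyl in place of fluoro on an aromatic carbon). Since every measured value sits at a limit, no direction is suggested by the data. The expectation is that compound 4 shows no step beyond the scatter in this assay, and the change from compound 3 to compound 4 is estimated as a step that the limit leaves unreadable from compound 3 to compound 4. Compound 4 is expected to give about 200000 nM in this assay, with a likely range from 100000 nM to 300000 nM, most probably again reported only as a limit.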

Compound 4, half-maximal effective concentration: > 180000 nM
Compound 4 was reported as a limit; the forecaster's own chance of this, stated with the estimate: 80%; the middle value lies beyond the limit too.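

Among these compounds, compound 3 and compound 4 both stand at a limit of the assay rather than at a number, and no step between them can be read in this assay. The compounds shown leave open what concentration, if any, would produce the effect for these compounds, and whether acetyl in place of fluoro on an aromatic carbon changes it.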